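From 2,6-dimethylphenyl to 5-chloro-2-methylphenyl on the amide

This account rests on a few compounds, and the source may have more. Where it says the series, first, only, none or still open, it means among the compounds named here.

Two aryl amides on the shared core have been read in an ADME assay on HEp-2 cells (Homo sapiens) for cytotoxicity; a higher number here means that more compound is tolerated, a lower number that less compound is tolerated. Compound 1 `Cc1cc(C)cc(NC(=O)[C@@H]2CCCN2S(=O)(=O)c2cccc3cccnc23)c1` gives 31300 nM. Compound 2 `Cc1cccc(C)c1NC(=O)[C@@H]1CCCN1S(=O)(=O)c1cccc2cccnc12` gives > 50000 nM, which is a limit of the assay and not a number. Compound 2 is therefore placed only by that limit: the limit of > 50000 nM in this assay, at which 1 of the 2 values shown sits.

Compound 3 `Cc1ccc(Cl)cc1NC(=O)[C@@H]1CCCN1S(=O)(=O)c1cccc2cccnc12` carries 5-chloro-2-methylphenyl in place of 2,6-dimethylphenyl on an amide-type nitrogen.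

For the measured compounds named here, one measured step bears on this change: an at least 1.5-fold higher number from compound 1 to compound 2 (0.20 log units; that floor lies within the scatter), a floor that lies within the scatter. Going by the values given here, that step also exchanges the aryl group on the amide-type nitrogen, but no chlorine-bearing compound has yet been read in this assay. Among the compounds with values here, with compound 1 at 31300 nM as the only true number, only a modest move to a lower number is expected, and possibly none beyond the scatter. The estimated change is an at least 1.3-fold lower number from compound 2 to compound 3 (0.11 log units; that floor lies within the scatter). Compound 3 is expected at 38000 nM, with an estimated range of 18000 nM to 75000 nM.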

Compound 3, half-maximal cytotoxic concentration: 10000 nM
Beside the measured number, compound 3's estimate is 3.8-fold (0.58 log units) above it, outside the stated range (below it).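

In this assay, the aryl group on the amide-type nitrogen now moves the read-out beyond the scatter, which the step between the two dimethylphenyl compounds could not show: 5-chloro-2-methylphenyl in place of 2,6-dimethylphenyl gives an at least 5.0-fold lower number from compound 2 to compound 3 (0.69 log units; beyond the scatter). For the compounds shown here, the comparison with the only other true number points the same way, with 5-chloro-2-methylphenyl in place of 3,5-dimethylphenyl giving a 3.1-fold lower number from compound 1 to compound 3 (0.50 log units; beyond the scatter), so compound 3 is the least tolerated of the three, and this position is not indifferent to the aryl group it carries. The first of these steps is a floor and not a full size because compound 2 is placed only by a limit of the assay: the limit of > 50000 nM in this assay, at which 1 of the 3 values shown sits.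

The three compounds do not separate the chlorine itself from the overall arrangement of groups on the aryl ring, since compound 3 differs from both dimethylphenyl compounds in more than the presence of that atom. On these data alone, how a bromine, a methoxy or a trifluoromethyl in place of the chlorine would read in this assay stays open, as does whether the lower number carries over to other amides on the shared core.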